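The compounds below may be only part of what the source reports. "The series", "measured", "known", "first", "only" and "open" are said of these compounds alone.

Measured so far in a functional assay on Huh-7 cells (Homo sapiens) for antiproliferative activity, read by sulforhodamine B assay, with a stated time of 72 h; on this read-out lower numbers stand for stronger inhibition and higher numbers for weaker inhibition: compound 1 `Cc1ccccc1COc1ccc(-c2cc(CN3CCN(Cc4ccc(C(F)(F)F)cc4)CC3)no2)cc1` gives 1200 nM; compound 2 `Cc1ccc(COc2ccc(-c3cc(CN4CCN(Cc5ccc(C(F)(F)F)cc5)CC4)no3)cc2)cc1` gives 1500 nM; compound 3 `FC(F)(F)c1ccc(CN2CCN(Cc3cc(-c4ccc(OCc5ccccc5Cl)cc4)on3)CC2)cc1` gives 1000 nM.

Compound 2 sits within the scatter of both other compounds, as the steps of a 1.3-fold higher number from compound 1 to compound 2 (0.10 log units; within the scatter) and a 1.5-fold lower number from compound 2 to compound 3 (0.18 log units; within the scatter) show. Compound 4 `N#Cc1ccc(COc2ccc(-c3cc(CN4CCN(Cc5ccc(C(F)(F)F)cc5)CC4)no3)cc2)cc1` differs from compound 2 by cyano in place of methyl on an aromatic carbon. For the measured compounds named here, no measured step swaps methyl for cyano; the nearest comparison is the other aromatic substituent exchange, a 1.2-fold lower number from compound 1 to compound 3 (0.08 log units; within the scatter), which stayed within the scatter, as did every step among the three measured compounds. Nothing in these numbers points to a move beyond the scatter in this assay for this change, so the expected step is a 1.2-fold lower number from compound 2 to compound 4 (0.06 log units; within the scatter). Compound 4 is therefore estimated at 1300 nM, with a range from 600 nM to 2800 nM.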

Compound 4, half-maximal inhibitory concentration: 1000 nM
Beside the measured number, compound 4's estimate is 1.3-fold (0.11 log units) above it; measured number inside the range.
By their numbers in this assay, from the lowest: compounds 3, 4, 1 and 2 (each within the scatter of the next).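

At this place, on an aromatic carbon para to a large group, cyano in place of methyl brings a hydrogen-bond acceptor, yet in this assay the number stays within the scatter (a 1.5-fold lower number from compound 2 to compound 4 (0.18 log units; within the scatter)). For the compounds shown here, the 4-cyanophenyl group also stays within the scatter of the 2-chlorophenyl and 2-methylphenyl groups (no change at the digits printed from compound 3 to compound 4 (within the scatter); a 1.2-fold lower number from compound 1 to compound 4 (0.08 log units; within the scatter)), so no step in this small set yet goes beyond it. Nothing available accounts for this result. On these data alone, whether an amine, a carboxylic acid or a longer chain at this place would move the number beyond the scatter remains open.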